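This account rests on a few compounds, and the source may have more. Where it says the series, first, only, none or still open, it means among the compounds named here.

Measured so far:
Compound 1 `O=C(CCCc1ccccc1)Nc1ccc(-c2nc3ccccc3[nH]2)cc1`: in an assay on cells for inhibition of matrix metalloproteinase-9 (Homo sapiens), read by fluorescence, with stated times of 15 min and 4 h (on this read-out lower numbers stand for stronger inhibition and higher numbers for weaker inhibition), compound 1 gives > 100000 nM, which is a limit of the assay and not a number.
Compound 2 `O=C(CCCc1ccccc1)Nc1ccc(-c2nc3ccc(Br)cc3[nH]2)cc1`: in this assay compound 2 gives 58000 nM.

Compound 1 stands at the limit of this assay, where one of the two values shown sits (the limit of > 100000 nM in this assay, at which 1 of the 2 values shown sits); nothing more than that is known of it. For the measured compounds named here, the only measured step, an at least 1.7-fold lower number from compound 1 to compound 2 (0.23 log units; that floor lies within the scatter), changes bromo for hydrogen on an aromatic carbon and rests on that limit. Compound 3 `O=C(CCc1ccccc1)Nc1ccc(-c2nc3ccccc3[nH]2)cc1` differs from compound 1 by phenyl in place of benzyl on a saturated chain carbon, two bonds along the chain from a carbonyl carbon. Going by the values given here, no measured step touches the chain on the amide side; the bromo step concerns a different part of the shared core and says nothing about the chain. Compound 3 is therefore expected to stay at or near the limit, an expected step that the limit leaves unreadable from compound 1 to compound 3 within the scatter. The estimate for compound 3 is 150000 nM, with an expected range from 40000 nM to 500000 nM.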

Compound 3, half-maximal inhibitory concentration: 29000 nM
For compound 3 the middle estimate is 5.2-fold (0.71 log units) above the measured one, outside the stated range (below it).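

In this assay phenyl in place of benzyl on a saturated chain carbon, two bonds along the chain from a carbonyl carbon, gives an at least 3.4-fold lower number from compound 1 to compound 3 (0.53 log units; beyond the scatter) and so shows that the chain on the amide side can move this read-out. The bromo step has a floor within the scatter, which leaves this chain change as the only step shown that clears it, with no hydrogen-bond donors, hydrogen-bond acceptors or net charge entering. The value of compound 1 is a limit and not a number, so only a floor is known for the size of this step: the limit of > 100000 nM in this assay, at which 1 of the 3 values shown sits.

Still open, as far as these compounds go, is whether a shorter chain, or an amine or a carboxylic acid in place of the phenyl at the chain end, changes the read-out further. Also open, from the compounds shown here alone, is whether bromo on the core of compound 3 adds to the chain change.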